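A few compounds are considered here, and "the series" means these few. Any claim that something is new, unique, unknown or untested is made for them only; others in the source may bear on it.

Measured compounds in an assay on 32D cells for inhibition of interleukin-15 (Mus musculus), read by resazurin assay, with stated times of 30 min and 2.5 days, in the presence of a further agent that is not named here; on this read-out lower numbers stand for stronger inhibition and higher numbers for weaker inhibition:
Compound 1, `CCOC(CCn1c(Cc2nn(C)c(=O)c3ccccc23)nnc1SCCCCCCCC(=O)Nc1ccc(Cl)cc1Cl)OCC`: 12100 nM
Compound 2, `Cn1nc(Cc2nnc(SCCCCCCCC(=O)Nc3ccc(Cl)cc3Cl)n2CCCO)c2ccccc2c1=O`: > 30000 nM, a limit of the assay
Compound 3, `Cn1c(Cc2nn(CCC3OCCO3)c(=O)c3ccccc23)nnc1SCC(=O)Nc1ccc(Cl)cc1Cl`: > 30000 nM, a limit of the assay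

Compound 3 stands at the ceiling of this assay: its value is a limit, not a number, so its true inhibition is only known to be no stronger than that limit. It shares this position with one other compound, since (the limit of > 30000 nM in this assay, at which 2 of the 3 values shown sit). Among the compounds with values here, the one measured step, an at least 2.4-fold higher number from compound 1 to compound 2 (0.39 log units; beyond the scatter), is the only guide to how changes on the chain that hangs from the aromatic nitrogen affect this assay, and it went toward weaker inhibition.

Compound 4, `Cn1c(Cc2nn(CCC=O)c(=O)c3ccccc23)nnc1SCC(=O)Nc1ccc(Cl)cc1Cl`, differs from compound 3 in exactly one place: formyl in place of 1,3-dioxolan-2-yl on a saturated chain carbon, two bonds along the chain from an aromatic nitrogen. Within the data shown here, no measured step covers a cyclic acetal turning into a formyl group, so the expectation rests on compound 3 already sitting at the limit and on the single related step having weakened inhibition rather than improved it. Compound 4 is therefore expected to stay at or near the limit, with a number no higher from compound 3 to compound 4 (the limit leaves the size open) as the estimated step. The estimate for compound 4 in this assay is 30000 nM, expected to lie between 10000 nM and 100000 nM.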

Compound 4, half-maximal inhibitory concentration: 30000 nM
The estimate for compound 4 equals the measured number at the digits printed; measured number inside the range.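

Replacing the 1,3-dioxolan-2-yl ring with the smaller formyl group, which has no ring, does not move inhibition clear of the top of the range in this assay: compound 4 gives a measured number rather than a limit (30000 nM). Compound 3, by contrast, gives only a limit of the assay (> 30000 nM). The change can therefore be stated only as a direction (a number no higher from compound 3 to compound 4 (the limit leaves the size open)), and its real size cannot be read because of that limit: the limit of > 30000 nM in this assay, at which 2 of the 4 values shown sit.

What the compounds shown leave open is whether any other group on this saturated chain carbon, two bonds along the chain from an aromatic nitrogen, would bring the number well below the top of the range, for example an amine or a carboxylic acid in place of the formyl group. Going by these compounds, it also remains open whether a longer chain ending in a formyl group would do the same, since a single comparison against a limit says little about how much this position can tolerate or gain.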